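Carbamate and benzoate esters of a shared core, antiproliferative read-out

This account rests on a few compounds, and the source may have more. Where it says the series, first, only, none or still open, it means among the compounds named here.

Measured compounds:
compound 1, `CC1=CC[C@H](C(C)C)c2cc(C)c(OC(=O)Nc3ccccc3)cc21`: 92.6%
compound 2, `CC1=CC[C@H](C(C)C)c2cc(C)c(OC(=O)c3ccc([N+](=O)[O-])cc3)cc21`: 89%
compound 3, `CC1=CC[C@H](C(C)C)c2cc(C)c(OC(=O)c3ccccc3)cc21`: "not active" (no number reported)

The series keeps one core and varies the acyl part on the phenolic oxygen. Within the data shown here, in a functional assay on K562 cells (Homo sapiens) for antiproliferative activity, read by sulforhodamine B assay, with a stated time of 48 h, tested at 50 uM (on this read-out lower numbers stand for less inhibition and higher numbers for more inhibition at the one concentration tested (going by the name of the read-out)), compound 1 gives 92.6%, and compound 2 gives 89%; the one measured step, a number 3.6 percentage points lower from compound 1 to compound 2 (within the scatter), lies within the scatter. Compound 3, the plain benzoate, stands apart: in this assay compound 3 is reported only as "not active" (no number reported), with no number given, while compound 2 with a nitro group on the same benzoate ring gives 89%.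

Compound 4, `CC1=CC[C@H](C(C)C)c2cc(C)c(OC(=O)c3cccc(C(F)(F)F)c3)cc21`, follows from compound 3 by the change (trifluoromethyl in place of hydrogen on an aromatic carbon). The place is an aromatic carbon of a six-membered aromatic ring of carbon only, meta to a large group. Among the measured compounds shown here, no measured step covers a trifluoromethyl on this ring, and no step covers a substituent placed meta on it; the step of a number 3.6 percentage points lower from compound 1 to compound 2 (within the scatter) concerns a different exchange and gives no direct size for this one. What the numbers show is that the unsubstituted benzoate compound 3 is reported as not active while the substituted benzoate compound 2 gives 89% in this assay, so the direction expected for compound 4 is upward from compound 3, with the size very uncertain. The estimate for compound 4 in this assay is 45%, ranging from 0% to 90%.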

Compound 4, a percentage reported as inhibition, at one concentration (the size of the read-out at that concentration, not a potency): 45.5%
The estimate for compound 4 lay 0.5 percentage points below the measured number; low and high end bracket the measured number.
By their numbers in this assay, from the lowest: compound 4; then compounds 2 and 1 (each within the scatter of the next).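

Among these compounds, no step from compound 3 to compound 4 can be read in this assay: compound 3 has no number, while compound 4 gives 45.5%. Nothing measured here points to a cause for this result. The compounds shown leave open how the read-out depends on the kind of group on the benzoate ring and on where it sits.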